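A Shorter Ester on the Shared Core of Compound 2

A few compounds are considered here, and "the series" means these few. Any claim that something is new, unique, unknown or untested is made for them only; others in the source may bear on it.

Compound 1 `CCOC(=O)c1sc2cccc(C)c2c1Nc1cc(OC)c(OC)c(OC)c1`: 2520 nM
Compound 2 `CCOC(=O)c1sc2ncccc2c1Nc1cc(OC)c(OC)c(OC)c1`: 2100 nM

In a functional assay on HeLa cells (Homo sapiens) for cytotoxicity, read by MTT assay, with a stated time of 72 h (on this read-out higher numbers stand for weaker inhibition and lower numbers for stronger inhibition), compound 2 gives 2100 nM, the low end of the two numbers, yet compound 1 at 2520 nM sits within the scatter of it, so the pair cannot be told apart. Compound 3 `COC(=O)c1sc2ncccc2c1Nc1cc(OC)c(OC)c(OC)c1` differs from compound 2 in a single place: hydrogen in place of methyl on a saturated chain carbon bound to an oxygen next to a carbonyl group. Among the measured compounds shown here, no measured pair shows this change, so in this assay a step of no size beyond the scatter is expected, in either direction. Compound 3 is estimated at 2500 nM, between 900 nM and 7000 nM. The expected step from compound 2 to compound 3 is a 1.2-fold higher number from compound 2 to compound 3 (0.08 log units; within the scatter).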

Compound 3, half-maximal inhibitory concentration: 342 nM
Compound 3: middle estimate off by 7.3-fold (0.86 log units), on the high side; measured number below the stated range.
By their numbers in this assay, from the lowest: compound 3; then compounds 2 and 1 (each within the scatter of the next).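

Replacing ethoxycarbonyl with methoxycarbonyl on the shared core gives a 6.1-fold lower number from compound 2 to compound 3 (0.79 log units; beyond the scatter) in this assay and shows that this ester is sensitive to the loss of a single methyl, which compounds 1 and 2 could not show, as they differ elsewhere. The change involves one hydrogen in place of one methyl and no ring, donor or charge, yet its step lies beyond the scatter. No measurement shown here offers an explanation for the step.

Still open, going by these compounds, is how a carboxylic acid, an amide or a longer chain such as propoxycarbonyl would read at this place. Also open, on these data alone, is whether methoxycarbonyl would give a similar step on the core of compound 1.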